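Thiophene for Tolyl on a Quinoline-Oxadiazole Cytotoxicity Series

The compounds below may be only part of what the source reports. "The series", "measured", "known", "first", "only" and "open" are said of these compounds alone.

Measured compounds: compound 1 `Cc1ccc(-c2nnc(-c3cc4ccccc4nc3C)o2)cc1`, 175 ug/mL; compound 2 `CC(=O)N1N=C(c2cc3ccccc3nc2C)CC1c1cccc(Oc2nc(Cl)c(Cl)cc2Cl)c1`, 72.7 ug/mL; compound 3 `Cc1nc2ccccc2cc1-c1nnc(-c2ccc(OC(F)(F)F)cc2)o1`, 91.1 ug/mL.

In an ADME assay on A549 cells (Homo sapiens) for cytotoxicity, read by MTT assay, with a stated time of 48 h (a higher number here means a weaker inhibitor, a lower number a stronger inhibitor), compound 1 gives the highest of the three numbers. Its nearest neighbour is compound 3, with a 1.9-fold lower number from compound 1 to compound 3 (0.28 log units; within the scatter). Compound 2 gives a lower number than compound 1, and the gap between the two is beyond the scatter.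

Compound 4 `Cc1nc2ccccc2cc1-c1nnc(-c2cccs2)o1` is not yet measured. It differs from compound 1 in thiophen-2-yl in place of 4-methylphenyl on an aromatic carbon. Among the measured compounds shown here, the only single-point step recorded, that from compound 1 to compound 3, changes a substituent on the same aryl ring rather than the ring itself, and it stays within the scatter. For the measured compounds named here, no step swapping the whole aryl group is available. Compound 4 is therefore expected to land near compound 1, with a 1.2-fold lower number from compound 1 to compound 4 (0.07 log units; within the scatter) estimated not to exceed the scatter, giving an expected 150 ug/mL with a range from 60 ug/mL to 380 ug/mL.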

Compound 4, half-maximal inhibitory concentration: 99.4 ug/mL
The estimate for compound 4 lay 1.5-fold (0.18 log units) above the measured number; low and high end bracket the measured number.
By their numbers in this assay, from the lowest: compounds 2, 3, 4 and 1 (each within the scatter of the next, the first and the last beyond it).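

In this assay, replacing the whole aryl ring rather than a substituent on it gives a 1.8-fold lower number from compound 1 to compound 4 (0.25 log units; within the scatter), so at this aromatic carbon the step from 4-methylphenyl to thiophen-2-yl stays inside the scatter. The substituent swap, a 1.9-fold lower number from compound 1 to compound 3 (0.28 log units; within the scatter), also stays inside it, so neither change at this position separates its pair of compounds. Nothing measured here offers an explanation for either step. The compounds shown leave open whether a non-aromatic group at this carbon, such as an amine or a carboxylic acid, would give a step beyond the scatter.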